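Dropping the sulfur link from a cyclohexyl-bearing vanilloid receptor antagonist

The source may report more compounds than this note shows. Statements on the series, on what has been measured and on what is new or still open speak of the compounds shown alone.

Of the compounds shown here, three sharing one core have been measured in an assay on CHO cells for antagonist activity at transient receptor potential cation channel subfamily V member 1 (Homo sapiens), read by FLIPR; on this read-out lower numbers stand for stronger inhibition and higher numbers for weaker inhibition. Compound 1 `CCCOc1cc(C(F)(F)F)ccc1CNC(=O)C(C)c1ccc(NS(C)(=O)=O)c(F)c1` gives 2 nM, compound 2 `CC(C(=O)NCc1ccc(C(F)(F)F)cc1OC1CCCCC1)c1ccc(NS(C)(=O)=O)c(F)c1` gives 0.7 nM, and compound 3 `CC(C(=O)NCc1ccc(C(F)(F)F)cc1SC1CCCCC1)c1ccc(NS(C)(=O)=O)c(F)c1` gives 0.5 nM, the lowest of the three numbers. The step of a 4.0-fold lower number from compound 1 to compound 3 (0.60 log units; beyond the scatter) lies beyond the scatter, while a 1.4-fold lower number from compound 2 to compound 3 (0.15 log units; within the scatter) lies within it. Compound 4 `CC(C(=O)NCc1ccc(C(F)(F)F)cc1C1CCCCC1)c1ccc(NS(C)(=O)=O)c(F)c1` carries cyclohexyl in place of cyclohexylsulfanyl on an aromatic carbon. Within the data shown here, no measured step removes a linking atom entirely; the closest guide is a 1.4-fold lower number from compound 2 to compound 3 (0.15 log units; within the scatter), where swapping oxygen for sulfur changed little, and a 2.9-fold lower number from compound 1 to compound 2 (0.46 log units; beyond the scatter), showing the cyclohexyl ring helps. A small step is therefore expected in this assay, a 2.0-fold higher number from compound 3 to compound 4 (0.30 log units; within the scatter), with compound 4 estimated at 1 nM, within a range of 0.3 nM to 3.5 nM.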

Compound 4, inhibition constant: 0.6 nM
The estimate for compound 4 lay 1.7-fold (0.22 log units) above the measured number; measured number inside the range.
By their numbers in this assay, from the lowest: compounds 3, 4 and 2 (each within the scatter of the next); then compound 1.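

In this assay the linking atom at this position can go altogether: joining the cyclohexyl ring straight to the aromatic carbon gives a 1.2-fold higher number from compound 3 to compound 4 (0.08 log units; within the scatter) and a 1.2-fold lower number from compound 2 to compound 4 (0.07 log units; within the scatter) with no real change. Sulfur, oxygen and no link at all therefore cannot be told apart among these compounds. Among these compounds, the cyclohexyl ring still separates from propoxy without any link, with a 3.3-fold lower number from compound 1 to compound 4 (0.52 log units; beyond the scatter) as the one step here beyond the scatter.

A propyl chain or a piperidine ring attached directly at this carbon remains an open case. Nothing available explains why the link matters so little.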